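A cyanosulfanyl-to-hydroxypentynyl swap on a deoxyuridine core

The source may hold more compounds than are shown below. What is called first, only, known or untested is meant among the compounds shown, and "the series" means these compounds.

In an ADME assay on L1210/0 cells (Mus musculus) for cytotoxicity, with a stated time of 48 h (a lower number here means a stronger inhibitor, a higher number a weaker inhibitor), compound 1 `COC1=C(OCc2ccc([N+](=O)[O-])cc2)C(=O)O/C1=C\Cn1cnc2c(Cl)ncnc21` gives 13600 nM and compound 2 `N#CSc1cn([C@H]2C[C@H](O)[C@@H](CO)O2)c(=O)[nH]c1=O` gives 78900 nM. Compound 3 `CC1(C)C(CO)CC1Cn1cnc2c(Cl)nc(N)nc21` reaches only the limit of this assay, > 200000 nM. Among the two plain numbers compound 2 sits highest, with compound 1 the nearer value; no single-place step joins any of the measured compounds. Compound 4 `O=c1[nH]c(=O)n([C@H]2C[C@H](O)[C@@H](CO)O2)cc1C#CCCCO` is not yet measured and differs from compound 2 at one site: 5-hydroxypent-1-yn-1-yl in place of cyanosulfanyl on an aromatic carbon. Among the measured compounds shown here, with no measured step to lean on, the step from compound 2 to compound 4 in this assay is expected to be small and toward a weaker number, quite possibly none beyond the scatter. For compound 4 the estimate is therefore 120000 nM, within 30000 nM to 500000 nM, a step of a 1.5-fold higher number from compound 2 to compound 4 (0.18 log units; within the scatter).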

Compound 4, half-maximal inhibitory concentration: > 200000 nM
Compound 4: a limit, no number; the forecaster's own chance of this, stated with the estimate: 35%; at least 1.6-fold (0.22 log units) between middle value and limit.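

At this aromatic carbon of the shared core, 5-hydroxypent-1-yn-1-yl in place of cyanosulfanyl gives an at least 2.5-fold higher number from compound 2 to compound 4 (0.40 log units; beyond the scatter) in this assay, the only single-place step shown, so this position does respond to the change. Compound 4 gives > 200000 nM, which is a limit of the assay and not a number. The full size of the step therefore stays unknown, as the reading ends at the limit: the limit of > 200000 nM in this assay, at which 2 of the 4 values shown sit.

The compounds shown leave open whether the chain itself or its terminal hydroxyl carries the step. They also leave open how a plain pent-1-yn-1-yl chain, a bromine or an amine at this carbon would read.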